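Iodo to thiophen-2-yl in a small inhibitor series

This account rests on a few compounds, and the source may have more. Where it says the series, first, only, none or still open, it means among the compounds named here.

Values in a functional assay on AGS cells (Homo sapiens) for inhibition, read by reporter gene assay; on this read-out higher numbers stand for weaker inhibition and lower numbers for stronger inhibition 
Compound 1 `O=C(COc1ccc(Cl)cc1)Nc1cccc(C(=O)O)c1` gives 10000 nM 
Compound 2 `O=C(COc1ccc(I)cc1)Nc1cccc(C(=O)O)c1` gives 3500 nM 

Compound 2 holds the lower of these two numbers. Compound 3 `O=C(COc1ccc(-c2cccs2)cc1)Nc1cccc(C(=O)O)c1` differs from compound 2 by thiophen-2-yl in place of iodo on an aromatic carbon with thiophen-2-yl in place of iodo on an aromatic carbon. Among the measured compounds shown here, the only measured step at this place is a 2.9-fold lower number from compound 1 to compound 2 (0.46 log units; beyond the scatter) and it is modest. That single step involves no ring, so it is thin guidance. A modest further fall in the number is expected in this assay but may stay within the scatter. The expected change is a 1.8-fold lower number from compound 2 to compound 3 (0.24 log units; within the scatter) as an estimate only. For compound 3 the estimated value is 2000 nM with an expected range from 600 nM to 7000 nM in this assay overall.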

Compound 3, half-maximal inhibitory concentration: > 30000 nM
Compound 3 was reported as a limit (the forecaster's own chance of this, stated with the estimate: 10%); middle value at least 15-fold (1.17 log units) from the limit.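

In this assay, this position does not reward every larger group: thiophen-2-yl in place of iodo reverses the fall in the number seen from chloro to iodo, giving an at least 8.5-fold higher number from compound 2 to compound 3 (0.93 log units; beyond the scatter). The ring also compares poorly with the smaller halogen, with an at least 3.0-fold higher number from compound 1 to compound 3 (0.47 log units; beyond the scatter). Compound 3 is known only through a limit, so both steps give only a minimum size: the limit of > 30000 nM in this assay, at which 1 of the 3 values shown sits.

The compounds shown leave open whether the loss belongs to thiophen-2-yl alone or to any aromatic ring at this position, such as phenyl. They also leave open how a methoxy group or an amine would behave here.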